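Replacing 2-bromophenyl with 3-fluoropyridin-2-yl on a shared core

This account rests on a few compounds, and the source may have more. Where it says the series, first, only, none or still open, it means among the compounds named here.

Compound 1 `CN(C)c1ccc2cc(-c3ccccc3Br)c(N)nc2c1` gives 12000 nM
Compound 2 `CN(C)c1ccc2cc(-c3ccc(Cl)cc3Cl)c(N)nc2c1` gives 8700 nM

Among the compounds with values here, in a toxicity assay on J774.A1 cells (Mus musculus) for cytotoxicity, read by SYBR Green assay, with a stated time of 1 h (a higher number here means that more compound is needed for the effect, a lower number that less compound is needed), compound 1 (12000 nM) and compound 2 (8700 nM) lie within the usual scatter of each other, so compound 1 stands level with the only other number measured. Compound 3 `CN(C)c1ccc2cc(-c3ncccc3F)c(N)nc2c1` has not yet been measured. It keeps the core of compound 1 and carries 3-fluoropyridin-2-yl in place of 2-bromophenyl on an aromatic carbon, ortho to an amino group (3-fluoropyridin-2-yl in place of 2-bromophenyl on an aromatic carbon). Within the data shown here, no measured pair shows a change at this place, so the data offer no direct guide to the size of the step. A modest move to a higher number in this assay is expected, though it may not clear the scatter by much. The estimate means a 1.7-fold higher number from compound 1 to compound 3 (0.22 log units; within the scatter) as the expected step. For compound 3 the expected value is 20000 nM with 8000 nM to 50000 nM as the estimated range.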

Compound 3, half-maximal effective concentration: 16000 nM
Compound 3: the middle estimate sits 1.3-fold (0.10 log units) above what was measured; measured number inside the range.
By their numbers in this assay, from the lowest: compounds 2, 1 and 3 (each within the scatter of the next).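

Within the data shown here, replacing 2-bromophenyl with 3-fluoropyridin-2-yl, on the aromatic carbon ortho to an amino group, gives the first step that can be read at this position: a 1.3-fold higher number from compound 1 to compound 3 (0.12 log units; within the scatter) in this assay. Among these compounds, an all-carbon aromatic ring can therefore be exchanged here for a ring holding one hetero atom without a shift that stands clear of the usual scatter, a point the earlier pair of compounds, which offered no step, could not address. No separate measurement bears on this result, and what lies behind it stays unexplained.

The compounds shown leave open whether a group of another kind at this position, such as an amine or a carboxylic acid, would give a step beyond the scatter. With a single step at this place, they also leave open whether the same exchange would read alike on a different core.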